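The source may report more compounds than this note shows. Statements on the series, on what has been measured and on what is new or still open speak of the compounds shown alone.

Compound 1 `O=C(NCc1ccc(S(=O)(=O)N2CCCCC2)cc1)c1ccn2cncc2c1` is an amide that joins a fused pair of aromatic rings to a benzylic amine whose phenyl ring carries a sulfonamide. In a functional assay on A2780 cells (Homo sapiens) for inhibition, read by sulforhodamine B assay, with a stated time of 72 h (on this read-out lower numbers stand for stronger inhibition and higher numbers for weaker inhibition), compound 1 gives > 10000 nM, which is a limit of the assay rather than a number. Two further compounds share the amide linkage but carry a sulfone in place of the sulfonamide. Compound 2 `O=C(NCc1ccc(S(=O)(=O)c2ccccc2)cc1)c1ccc2nncn2c1` gives > 10000 nM in this assay, again a limit and not a number. Compound 3 `O=C(NCc1ccc(S(=O)(=O)c2ccccc2)cc1)c1ccc2nccn2c1` gives 13 nM in this assay. The step of an at least 760-fold lower number from compound 2 to compound 3 (2.88 log units; beyond the scatter) shows that exchanging one fused ring pair on the carbonyl carbon for another can carry a compound from the limit of > 10000 nM in this assay, at which 2 of the 3 values shown sit, to strong inhibition, so the make-up of that ring pair matters greatly. Compound 4 `O=C(NCc1ccc(S(=O)(=O)N2CCCCC2)cc1)c1ccn2ccnc2c1` is not yet measured; it differs from compound 1 only by a group of 9 heavy atoms (7 carbon, 2 nitrogen; one five-membered aromatic ring with 2 hetero atoms, one six-membered aromatic ring with 1 hetero atom) in place of a group of 9 heavy atoms (7 carbon, 2 nitrogen; one five-membered aromatic ring with 2 hetero atoms, one six-membered aromatic ring with 1 hetero atom), on a carbonyl carbon. The ring pair that enters in compound 4 has the same atoms as the ring pair of compound 3, joined differently, while compound 1 sits at the limit. A step of the kind seen from compound 2 to compound 3 is possible, but compound 4 keeps the sulfonamide of compound 1 rather than the sulfone of compound 3, so the size is uncertain. Compound 4 is therefore expected to improve on compound 1 by an at least 20-fold lower number from compound 1 to compound 4 (1.30 log units; beyond the scatter), to an estimated 500 nM, between 30 nM and 10000 nM.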

Compound 4, half-maximal inhibitory concentration: > 10000 nM
Compound 4: no number, only a limit; the forecaster's own chance of this, stated with the estimate: 35%; middle value at least 20-fold (1.30 log units) from the limit.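

Compound 1 and compound 4 both stand at a limit of this assay rather than at a number, so the step between them cannot be read: the limit of > 10000 nM in this assay, at which 3 of the 4 values shown sit.

The compounds shown leave open how far either of these two lies beyond that limit, and whether the ring pair of compound 3 would still give strong inhibition alongside the sulfonamide.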